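Notes on ring-nitrogen substituents, compounds 1 to 4

The compounds below may be only part of what the source reports. "The series", "measured", "known", "first", "only" and "open" are said of these compounds alone.

Measured so far in an assay for inhibition of Tryptophan 2,3-dioxygenase (Homo sapiens), with a stated time of 1 h; on this read-out lower numbers stand for stronger inhibition and higher numbers for weaker inhibition:
compound 1, `NS(=O)(=O)NC[C@H]1CC[C@H](C(=O)/C(=N/O)Nc2ccc(F)c(Br)c2)CC1`, gives 58700 nM
compound 2, `O=C(/C(=N/O)Nc1ccc(F)c(Br)c1)C1CCN(S(=O)(=O)Nc2ccccc2)CC1`, gives 65700 nM
compound 3, `O=C(/C(=N/O)Nc1ccc(F)c(Br)c1)C1CCN(c2ccccc2)CC1`, gives > 100000 nM

Compound 3 returns only a limit of the assay, not a number: it sits at the limit of > 100000 nM in this assay, at which 1 of the 3 values shown sits. So compound 3 stands at the weak end of what this assay can report, and the single step leading to it, an at least 1.5-fold higher number from compound 2 to compound 3 (0.18 log units; that floor lies within the scatter), has a floor that lies within the scatter; only its direction, toward weaker inhibition, is secure.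

Compound 4, `O=C(/C(=N/O)Nc1ccc(F)c(Br)c1)C1CCN(C(=O)Nc2ccccc2)CC1`, carries phenylcarbamoyl in place of phenyl on an amine nitrogen in a ring. That change reverses the sense of the step from compound 2 to compound 3: a carbonyl-linked phenyl returns to the ring nitrogen in place of a bare phenyl, with a donor and an acceptor entering as counted. Within the data shown here, the only measured step that bears on it is an at least 1.5-fold higher number from compound 2 to compound 3 (0.18 log units; that floor lies within the scatter), and its reverse is the expected size and direction here, an at least 1.4-fold lower number from compound 3 to compound 4 (0.15 log units; that floor lies within the scatter), with the reading of compound 2 as the natural anchor. Compound 4 is therefore expected at about 70000 nM, in the range 30000 nM to 200000 nM.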

Compound 4, half-maximal inhibitory concentration: 58000 nM
Estimate against measurement, compound 4: 1.2-fold (0.08 log units) above, and the stated range covers the measured number.
By their numbers in this assay, from the lowest: compounds 4, 1 and 2 (each within the scatter of the next). At a limit, above all of these: compound 3.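

Compound 3 is a limit of the assay and not a number: the limit of > 100000 nM in this assay, at which 1 of the 4 values shown sits.

In this assay the step to phenylcarbamoyl in place of phenyl on the ring nitrogen is an at least 1.7-fold lower number from compound 3 to compound 4 (0.23 log units; that floor lies within the scatter), so its direction is secure but its size is only a floor. With phenylsulfamoyl replaced by the same group, the step is a 1.1-fold lower number from compound 2 to compound 4 (0.05 log units; within the scatter), so the carbonyl and sulfonyl links to the phenyl cannot be told apart at this position.

As far as these compounds go, the true size of the gap between the bare phenyl and the linked phenyl groups remains open, as does whether any group at this position can move the number beyond the scatter of these values. An acetyl group or a benzyl group on the ring nitrogen would help to separate the contribution of the carbonyl from that of the phenyl.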